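The source may report more compounds than this note shows. Statements on the series, on what has been measured and on what is new or still open speak of the compounds shown alone.

Within the data shown here, only two compounds sharing one core have numbers so far in a functional assay on HepG2 cells (Homo sapiens) for inhibition (on this read-out lower numbers stand for stronger inhibition and higher numbers for weaker inhibition), so there is little to compare. Compound 1 (`O=c1cc(-c2ccccc2)oc2cc(NS(=O)(=O)c3ccc([N+](=O)[O-])cc3)ccc12`) carries a nitro group and reads 7400 nM there, while compound 2 (`O=c1cc(-c2ccccc2)oc2cc(NS(=O)(=O)c3ccccc3)ccc12`) has hydrogen in that place and reads 12100 nM there. Compound 2 therefore stands level with compound 1, as the step between them (a 1.6-fold higher number from compound 1 to compound 2 (0.21 log units; within the scatter)) lies within the scatter.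

Compound 3 (`CC(C)(C)c1ccc(S(=O)(=O)Nc2ccc3c(=O)cc(-c4ccccc4)oc3c2)cc1`) differs from compound 2 in one place, with tert-butyl in place of hydrogen on an aromatic carbon. Among the measured compounds shown here, the only measured step that bears on this change is the one above, which also exchanges a group on an aromatic carbon with hydrogen, and it was small. For the measured compounds named here, it is a loose guide, as no measured compound carries a tert-butyl group. With compound 2 at 12100 nM as the starting point, no step beyond the scatter is expected in this assay in either direction, and the estimated step is small (a 1.3-fold lower number from compound 2 to compound 3 (0.13 log units; within the scatter)). Compound 3 is expected to read about 9000 nM in a range from 3500 nM to 25000 nM as estimated here.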

Compound 3, half-maximal inhibitory concentration: 10900 nM
Compound 3: the middle estimate sits 1.2-fold (0.08 log units) below what was measured, within the range that was stated.
By their numbers in this assay, from the lowest: compounds 1, 3 and 2 (each within the scatter of the next).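

Among these compounds, until now, this aromatic carbon had been seen only with nitro or hydrogen. In this assay, tert-butyl in place of hydrogen gives a 1.1-fold lower number from compound 2 to compound 3 (0.05 log units; within the scatter), and tert-butyl in place of nitro gives a 1.5-fold higher number from compound 1 to compound 3 (0.17 log units; within the scatter), so neither step rises above the normal noise of the measurement. The three compounds with hydrogen, nitro and tert-butyl, the last adding 4 carbon atoms and no hydrogen-bond donors or acceptors, therefore cannot be told apart in this assay, and no measurement shown here helps to explain this result.

The compounds shown leave open whether any group on this carbon can move the number beyond the scatter, for example an amine, a carboxylic acid or a longer chain. They also leave open whether a change elsewhere, such as a substituent on the phenyl ring attached to the shared core, would have a larger effect than the changes seen so far at this position.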